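This account rests on a few compounds, and the source may have more. Where it says the series, first, only, none or still open, it means among the compounds named here.

Measured in a functional assay on A549 cells (Homo sapiens) for antiproliferative activity, read by MTT assay, with a stated time of 48 h; a higher number here means a weaker inhibitor, a lower number a stronger inhibitor:
- compound 1 (`COc1ccc(C(=O)c2cc(OC)c(OC)c(OC)c2)c(NC(=O)CO)c1`) gives 70 nM here
- compound 2 (`CCNCC(=O)Nc1cc(OC)ccc1C(=O)c1cc(OC)c(OC)c(OC)c1`) gives 750 nM here

Among the compounds with values here, compound 2 holds the higher of the two numbers, with an 11-fold higher number from compound 1 to compound 2 (1.03 log units; beyond the scatter) as the only measured step, and that step is large. Compound 3 (`COc1ccc(C(=O)c2cc(OC)c(OC)c(OC)c2)c(NC(=O)CN(C)C)c1`) is still unmeasured. It carries dimethylamino in place of ethylamino on a saturated chain carbon bound to a carbonyl carbon, counted as dimethylamino in place of ethylamino on a saturated chain carbon bound to a carbonyl carbon and leaving the rest of the structure unchanged.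

The measured step bears on this change only indirectly. It concerns the same place, but it replaced hydroxy with ethylamino, and no two amino groups have yet been compared there. Compound 3 keeps an amino group at that place, so its number is expected to stay near compound 2 at 750 nM and not to return towards compound 1 at 70 nM in this series. Within the data shown here, the expected change is a 1.2-fold lower number from compound 2 to compound 3 (0.06 log units; within the scatter) and no step beyond the scatter is expected, though the wide range reflects the single precedent. Compound 3 is estimated at 650 nM with 200 nM to 2000 nM as the expected range in this assay for this measurement.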

Compound 3, half-maximal inhibitory concentration: 590 nM
Compound 3: middle estimate off by 1.1-fold (0.04 log units), on the high side, within the range that was stated.
By their numbers in this assay, from the lowest: compound 1; then compounds 3 and 2 (each within the scatter of the next).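

In this assay, dimethylamino in place of ethylamino on a saturated chain carbon bound to a carbonyl carbon gives a 1.3-fold lower number from compound 2 to compound 3 (0.10 log units; within the scatter) and so does not separate these two amino groups at this place, although ethylamino is counted with a hydrogen-bond donor and dimethylamino with none. The comparison with hydroxy now rests on a second amino group, with an 8.4-fold higher number from compound 1 to compound 3 (0.93 log units; beyond the scatter) and thus a gap beyond the scatter, so both amino compounds shown stand apart from compound 1 and none of the three goes against this. No measurement at hand bears on what lies behind these numbers.

Going by these compounds, two amino groups are a narrow sample, so it remains open whether a ring amine such as morpholine or piperidine, or a longer chain carrying the amine, would stay near compounds 2 and 3 or move towards compound 1. On these data alone, it is equally open whether methoxy or an unsubstituted amino group at this place would side with hydroxy or with the two amino groups, and a carboxylic acid there would test the same question from a further direction.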